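Fluorine shift on the benzyl arm: solubility notes

This account rests on a few compounds, and the source may have more. Where it says the series, first, only, none or still open, it means among the compounds named here.

Measured so far:
- compound 1, `CNC(=O)c1cc(C(=O)NC2CC2)cn(Cc2cccc(F)c2)c1=O`: >= 133 ug/mL
- compound 2, `CNC(=O)c1cccn(Cc2ccccc2)c1=O`: 78 ug/mL
- compound 3, `CNC(=O)c1cc(C(=O)NC)c(=O)n(Cc2ccccc2)c1`: >= 118 ug/mL

Compound 1 is known only as a limit in a physicochemical assay for solubility; on this read-out higher numbers stand for higher solubility and lower numbers for lower solubility: its value of >= 133 ug/mL is a ceiling of the assay, not a number, as set out in the limit of >= 133 ug/mL in this assay, at which 1 of the 3 values shown sits. Compound 3 likewise sits at a limit, >= 118 ug/mL, described in the limit of >= 118 ug/mL in this assay, at which 1 of the 3 values shown sits. Within the data shown here, compound 2 is the one measured number in the set, 78 ug/mL.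

The unmeasured compound 4, `CNC(=O)c1cc(C(=O)NC2CC2)cn(Cc2ccccc2F)c1=O`, differs from compound 1 by 2-fluorophenyl in place of 3-fluorophenyl on a saturated chain carbon bound to an aromatic nitrogen.

Among the measured compounds shown here, the single measured step, an at least 1.5-fold higher number from compound 2 to compound 3 (0.17 log units; that floor lies within the scatter), concerns a methylcarbamoyl group on the core and not the benzyl arm, so it does not bear on the present change. For the measured compounds named here, no step among the measured compounds touches the fluorine position, and the pair compound 1 to compound 4 has no measured counterpart.

With no evidence for a shift in either direction, compound 4 is expected to stay close to compound 1, an at least 1.0-fold lower number from compound 1 to compound 4 (0.00 log units; that floor lies within the scatter), and most likely at the assay limit again. The estimate for compound 4 in this assay is 130 ug/mL, within 60 ug/mL to 260 ug/mL.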

Compound 4, solubility: >= 145 ug/mL
Compound 4: no number, only a limit (the forecaster's own chance of this, stated with the estimate: 60%); middle value at least 1.1-fold (0.04 log units) from the limit.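

The step between compound 1 and compound 4 cannot be read, as both stand only as limits in this assay. The compounds shown leave open whether 2-fluorobenzyl in place of 3-fluorobenzyl changes the read-out in this assay at all, and in which direction.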